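The source may hold more compounds than are shown below. What is called first, only, known or untested is meant among the compounds shown, and "the series" means these compounds.

Measured so far:
compound 1 `NCc1ccc(C(=O)Nc2ccncc2F)cc1-c1cccc(NC(=O)c2cc(C(=O)O)ccc2F)c1`: < 1 nM
compound 2 `NCc1ccc(C(=O)Nc2ccncc2F)cc1-c1cccc(C(=O)Nc2cccc(CC(=O)O)c2)c1`: 1.5 nM

In an assay on cells for inhibition of Rho-associated protein kinase 2 (Homo sapiens), read by radiometric assay and 33P incorporation, in the presence of a further agent that is not named here (on this read-out higher numbers stand for weaker inhibition and lower numbers for stronger inhibition), compound 1 gives < 1 nM, which is a limit of the assay and not a number; this is the limit of < 1 nM in this assay, at which 1 of the 2 values shown sits. Compound 2 gives 1.5 nM in this assay. For the measured compounds named here, no step between two measured compounds that differ in one place is available, so the two values show only that both compounds sit at the strong end of the measured range.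

Compound 3 `COC(=O)c1ccc(F)c(C(=O)Nc2cccc(-c3cc(C(=O)Nc4ccncc4F)ccc3CN)c2)c1` differs from compound 1 by methyl in place of hydrogen on an oxygen next to a carbonyl group. Nothing measured in this series fixes the size of such a change, and the starting point itself is a limit. The step from compound 1 to compound 3 is expected to be an at least 3.0-fold higher number from compound 1 to compound 3 (0.47 log units; beyond the scatter), towards weaker inhibition, and modest. Compound 3 is estimated at 3 nM in this assay, within 0.8 nM to 12 nM.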

Compound 3, half-maximal inhibitory concentration: < 1 nM
Compound 3 was reported as a limit; the forecaster's own chance of this, stated with the estimate: 15%; middle value at least 3.0-fold (0.47 log units) away from the limit.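

Compound 1 and compound 3 are both reported as limits and not as numbers, so no size can be read for the change from carboxy to methoxycarbonyl: the limit of < 1 nM in this assay, at which 2 of the 3 values shown sit.

The compounds shown leave open how far either compound lies beyond that limit, and whether this change alters inhibition at all.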